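A few compounds are considered here, and "the series" means these few. Any claim that something is new, unique, unknown or untested is made for them only; others in the source may bear on it.

Working notes on the cytotoxicity series.

Compound 1 `Cc1ccc(/C=C2/S/C(=N/c3ccccc3)N(Cc3ccncc3)C2=O)cc1` is assessed in an ADME assay on HEK293 cells (Homo sapiens) for cytotoxicity, read by MTT assay, with a stated time of 48 h (on this read-out lower numbers stand for stronger inhibition and higher numbers for weaker inhibition), where compound 1 gives 49500 nM. Among the three measured numbers this places compound 1 second highest; its nearest neighbour is compound 2 `COc1ccc(/C=C2/S/C(=N/c3ccccc3)N(Cc3ccncc3)C2=O)cc1`, which in this assay gives 47900 nM, and the step of a 1.0-fold lower number from compound 1 to compound 2 (0.01 log units; within the scatter) lies within the scatter. The furthest is compound 3 `O=C1/C(=C\c2ccc(O)c(O)c2)S/C(=N/c2ccccc2)N1Cc1ccncc1`, which in this assay gives 230000 nM; the step of a 4.6-fold higher number from compound 1 to compound 3 (0.67 log units; beyond the scatter) and the parallel step a 4.8-fold higher number from compound 2 to compound 3 (0.68 log units; beyond the scatter) are the only moves beyond the scatter so far. Both of these steps change the group at the same place as the one now considered.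

Compound 4 `O=C1/C(=C\c2ccccn2)S/C(=N/c2ccccc2)N1Cc1ccncc1` differs from compound 1 as follows: pyridin-2-yl in place of 4-methylphenyl on a double-bonded chain carbon bound to a double-bonded ring carbon. For the measured compounds named here, no measured step introduces a ring nitrogen at this place, so the two steps to compound 3 are the only guide, and they show that a change of the aryl group there can move this assay by a modest amount, toward higher numbers. A step of that order at most, or none beyond the scatter, is the expectation for compound 4, with a slight lean toward a higher number, as the step of a 1.3-fold higher number from compound 1 to compound 4 (0.12 log units; within the scatter) is estimated.

For compound 4 the expected value in this assay is 65000 nM, with a range from 25000 nM to 170000 nM.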

Compound 4, half-maximal inhibitory concentration: 161000 nM
Beside the measured number, compound 4's estimate is 2.5-fold (0.39 log units) below it; low and high end bracket the measured number.
By their numbers in this assay, from the lowest: compounds 2 and 1 (each within the scatter of the next); then compounds 4 and 3 (each within the scatter of the next).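

In this assay, pyridin-2-yl on a double-bonded chain carbon bound to a double-bonded ring carbon gives a 3.3-fold higher number from compound 1 to compound 4 (0.51 log units; beyond the scatter) and a 3.4-fold higher number from compound 2 to compound 4 (0.53 log units; beyond the scatter), so a move toward higher numbers at this place is no longer tied to 3,4-dihydroxyphenyl alone. The step of a 1.4-fold lower number from compound 3 to compound 4 (0.15 log units; within the scatter) does not separate pyridin-2-yl from 3,4-dihydroxyphenyl, and the four compounds now form two sets at this place: compounds 1 and 2 with their 4-substituted phenyl groups, and compounds 3 and 4 with clearly higher numbers than either member of that first set. No measurement at hand accounts for this split, and the reason for it remains unknown.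

Compound 4 both brings in a ring nitrogen and removes the methyl group of compound 1, so the compounds shown cannot assign the step to either change; plain phenyl, pyridin-3-yl and pyridin-4-yl at this place would help separate the two. Also open, on these data alone, is how an aryl group carrying an amine or a carboxylic acid at this place would read in this assay, and whether the two sets would persist.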